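A few compounds are considered here, and "the series" means these few. Any claim that something is new, unique, unknown or untested is made for them only; others in the source may bear on it.

Compound 2 `c1ccc(OCc2nc3c(OCCCN4CCCCC4)cccc3n2CCCC2CCNCC2)cc1` gives 4.5 nM in an in vitro assay on AV12 cells for binding affinity to Neuropeptide Y receptor type 1 (Homo sapiens) (on this read-out lower numbers stand for stronger inhibition and higher numbers for weaker inhibition), the highest of the three numbers shown. Compound 1 `c1ccc(OCc2nc3c(OCCCN4CCCCC4)cccc3n2CCCC2CCN(CCC3CCCCC3)CC2)cc1` gives 0.285 nM, and compound 3 `c1ccc(CCCN2CCC(CCCn3c(COc4ccccc4)nc4c(OCCCN5CCCCC5)cccc43)CC2)cc1` gives 0.361 nM. Compound 4 `O=C(CCCN1CCC(CCCn2c(COc3ccccc3)nc3c(OCCCN4CCCCC4)cccc32)CC1)c1ccccc1` differs from compound 2 in one place: 3-benzoylpropyl in place of hydrogen on an amine nitrogen in a ring. Going by the values given here, two measured steps bear on this change, both placing a substituent on the same ring nitrogen: a 12-fold lower number from compound 2 to compound 3 (1.10 log units; beyond the scatter), and a 16-fold higher number from compound 1 to compound 2 (1.20 log units; beyond the scatter). Both are large and beyond the scatter, so a comparable drop in this assay is expected for compound 4, since the entering group shares its aromatic ring and chain length with the 3-phenylpropyl of compound 3. The estimated step is a 9.0-fold lower number from compound 2 to compound 4 (0.95 log units; beyond the scatter). Compound 4 is therefore expected to give about 0.5 nM, within a range of 0.15 nM to 1.6 nM.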

Compound 4, inhibition constant: 0.132 nM
Beside the measured number, compound 4's estimate is 3.8-fold (0.58 log units) above it; measured number outside the range, below it.
By their numbers in this assay, from the lowest: compound 4; then compounds 1 and 3 (each within the scatter of the next); then compound 2.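

In this assay the ring nitrogen takes the 3-benzoylpropyl group with the largest step yet seen at this position (a 34-fold lower number from compound 2 to compound 4 (1.53 log units; beyond the scatter)). Benzoyl in place of phenyl still gives a modest gain (a 2.7-fold lower number from compound 3 to compound 4 (0.44 log units; beyond the scatter)), so the carbonyl-bearing chain does not merely match the hydrocarbon substituents. The same holds against the 2-cyclohexylethyl group (a 2.2-fold lower number from compound 1 to compound 4 (0.33 log units; beyond the scatter)).

Nothing shown explains why the benzoyl group does better. Going by these compounds, whether a hydroxyl in place of the carbonyl, or a longer chain carrying the benzoyl, would keep this gain remains open.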